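The source may report more compounds than this note shows. Statements on the series, on what has been measured and on what is new or still open speak of the compounds shown alone.

Compound 1 `COc1cccc(Cn2cc(CCCCC[C@@H]3SC[C@@H]4NC(=O)N[C@@H]43)nn2)c1` carries a 3-methoxyphenyl group on a saturated chain carbon bound to an aromatic nitrogen. In an assay on isolated protein for inhibition of biotin--protein ligase (Homo sapiens), read by scintillation counting, with a stated time of 10 min (a lower number here means a stronger inhibitor, a higher number a weaker inhibitor), compound 1 gives > 16000 nM, which is a limit of the assay rather than a number. Compound 2 `O=C1N[C@H]2[C@H](CS[C@H]2CCCCCc2cn(Cc3ccc(I)cc3)nn2)N1` differs from compound 1 only in the group on that carbon. In this assay compound 2 gives > 16000 nM, again a limit and not a number. The step that the two limits leave unreadable from compound 1 to compound 2 therefore cannot be read, and compound 2 stands at the limit of > 16000 nM in this assay, at which 2 of the 2 values shown sit. Compound 3 `O=C1N[C@H]2[C@H](CS[C@H]2CCCCCc2cn(Cc3ccccc3F)nn2)N1` carries the change (2-fluorophenyl in place of 4-iodophenyl on a saturated chain carbon bound to an aromatic nitrogen). For the measured compounds named here, the only measured step is likewise an exchange of one group on this carbon, and both of its ends are limits, so it gives no size to lean on. The expected step that the limit leaves unreadable from compound 2 to compound 3 is small, with a further limit the most likely outcome. Compound 3 is expected to give 25000 nM, within 6000 nM to 100000 nM.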

Compound 3, inhibition constant: > 16000 nM
Compound 3: no number, only a limit; the forecaster's own chance of this, stated with the estimate: 80%; the middle value does not contradict the limit.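

In this assay compound 3 gives > 16000 nM, a limit and not a number. The steps to compound 3 from compound 1 and compound 2 therefore cannot be read: the limit of > 16000 nM in this assay, at which 3 of the 3 values shown sit.

The compounds shown leave open how strongly each one actually inhibits, and whether exchanging the group on this carbon changes that at all.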